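The source may hold more compounds than are shown below. What is called first, only, known or untested is meant among the compounds shown, and "the series" means these compounds.

Among the compounds with values here, in a toxicity assay on Vero cells (Chlorocebus sabaeus) for cytotoxicity (on this read-out higher numbers stand for lower toxicity in this test and lower numbers for higher toxicity in this test), compound 1 `COc1nc(-c2ccsc2)ccc1[C@@H](c1ccccc1)[C@@](O)(CCN(C)C)c1cccc2ccccc12` gives 24.4 ug/mL, the only actual number so far. Compound 2 `COc1ncc(-c2ccccc2)cc1[C@@H](c1ccccc1)[C@@](O)(CCN(C)C)c1cccc(F)c1F` gives > 50 ug/mL, which is a limit of the assay and not a number. Compound 3 `COc1nc(-c2ccc(OC(F)(F)F)cc2)ccc1[C@@H](c1ccccc1)[C@@](O)(CCN(C)C)c1cccc2ccccc12` carries 4-(trifluoromethoxy)phenyl in place of thiophen-3-yl on an aromatic carbon of the core of compound 1 (4-(trifluoromethoxy)phenyl in place of thiophen-3-yl on an aromatic carbon). Within the data shown here, no measured pair shows what such a swap does, so the expected step of a 1.1-fold lower number from compound 1 to compound 3 (0.04 log units; within the scatter) is none beyond the usual scatter. For compound 3 the estimated value is 22 ug/mL, with an expected range from 9 ug/mL to 50 ug/mL.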

Compound 3, half-maximal cytotoxic concentration: > 50 ug/mL
Compound 3: only a limit was reported; the forecaster's own chance of this, stated with the estimate: 15%; middle value at least 2.2-fold (0.35 log units) from the limit.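

In this assay, placing 4-(trifluoromethoxy)phenyl instead of thiophen-3-yl on this aromatic carbon next to the ring nitrogen gives an at least 2.0-fold higher number from compound 1 to compound 3 (0.31 log units; beyond the scatter). Within the data shown here, this is the first sign that a change at this position can shift the read-out, here toward lower toxicity in this test. For compound 3 the value is a limit and not a number, so the full size of the step cannot be read: the limit of > 50 ug/mL in this assay, at which 2 of the 3 values shown sit.

From the compounds shown here alone, what an amine or a carboxylic acid at this position would do remains open. So does whether a plain phenyl ring, without the trifluoromethoxy group, would give the same shift.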